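The compounds below may be only part of what the source reports. "The series", "measured", "known", "first", "only" and "open" are said of these compounds alone.

In an ADME assay on microsomes from liver (Homo sapiens) for metabolic stability, read by LC-MS, tested at 1 uM (a lower number here means slower removal, a higher number faster removal of the compound), compound 1 `CC(C)(O)CN1CCC(Oc2ccc([C@H]3CC[C@]4(CC3)OOC3(O4)C4CC5CC(C4)CC3C5)cc2)CC1` gives 18 mL.min-1.g-1. Compound 2 `c1cc([C@H]2CC[C@]3(CC2)OOC2(O3)C3CC4CC(C3)CC2C4)ccc1OCCC1CCNCC1` gives < 7 mL.min-1.g-1, which is a limit of the assay and not a number. From the compounds shown here alone, it therefore stands at the limit of < 7 mL.min-1.g-1 in this assay, at which 1 of the 2 values shown sits, and its true position is unknown. Compound 3 `c1cc([C@H]2CC[C@]3(CC2)OOC2(O3)C3CC4CC(C3)CC2C4)ccc1OC1CCNCC1` differs from compound 2 as follows: piperidin-4-yl in place of 2-(piperidin-4-yl)ethyl on an oxygen on an aromatic ring. For the measured compounds named here, one measured step bears on this change at the same place, on an oxygen on an aromatic ring: an at least 2.5-fold lower number from compound 1 to compound 2 (0.41 log units; beyond the scatter). That step lies beyond the scatter, but its size is only a bound, and it involves a different exchange of groups. Going by the values given here, no measured pair isolates the change from 2-(piperidin-4-yl)ethyl to piperidin-4-yl. With that single step as a guide, the expected change is a number no lower from compound 2 to compound 3 (the limit leaves the size open), with no shift beyond the scatter in either direction. For compound 3, the estimated value in this assay is 7 mL.min-1.g-1, with an expected range from 4 mL.min-1.g-1 to 16 mL.min-1.g-1.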

Compound 3, intrinsic clearance in microsomes: 15 mL.min-1.g-1
Compound 3: the middle estimate sits 2.1-fold (0.33 log units) below what was measured, within the range that was stated.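

In this assay, the exchange of 2-(piperidin-4-yl)ethyl for piperidin-4-yl on an oxygen on an aromatic ring, now seen apart from any other difference, gives an at least 2.1-fold higher number from compound 2 to compound 3 (0.33 log units; beyond the scatter). Hydrogen in place of 2-hydroxy-2-methylpropyl on an amine nitrogen in a ring gives a 1.2-fold lower number from compound 1 to compound 3 (0.08 log units; within the scatter), so of the two differences folded into the earlier step, only the one on the oxygen shows a shift beyond the scatter. Compound 2 carries a limit and not a number, so the first of these steps gives only a bound on the size: the limit of < 7 mL.min-1.g-1 in this assay, at which 1 of the 3 values shown sits.

From the compounds shown here alone, how far compound 2 truly lies from compound 3 remains open. Also open, going by these compounds, is how a longer chain such as 3-(piperidin-4-yl)propyl, or a methyl group on the amine nitrogen of compound 3, would read in this assay.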